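A Sulfamoylphenyl Change on a Core at the Assay Limit

The source may report more compounds than this note shows. Statements on the series, on what has been measured and on what is new or still open speak of the compounds shown alone.

Compound 1 `N#CC1=C(N)Oc2c(c3nc4ccccc4nc3c3ccccc23)C12C(=O)N(Cc1cnnn1-c1ccccc1Br)c1ccccc12` was tested in a functional assay on HCT-116 cells (Homo sapiens) for antiproliferative activity, read by MTT assay, with a stated time of 48 h; on this read-out higher numbers stand for weaker inhibition and lower numbers for stronger inhibition. In this assay compound 1 reaches only the limit of > 50000 nM, so its standing is known just as a limit, not as a number. Compound 2 `COc1ccc(-n2nncc2CN2C(=O)C3(C(C#N)=C(N)Oc4c3c3nc5ccccc5nc3c3ccccc43)c3ccccc32)cc1` carries a 4-methoxyphenyl in place of the 2-bromophenyl on the aromatic nitrogen. In this assay compound 2 also gives only the limit of > 50000 nM. The step that the two limits leave unreadable from compound 1 to compound 2 is therefore unreadable, because both of its values sit at the limit of > 50000 nM in this assay, at which 2 of the 2 values shown sit.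

Compound 3 `N#CC1=C(N)Oc2c(c3nc4ccccc4nc3c3ccccc23)C12C(=O)N(Cc1cnnn1-c1ccc(S(N)(=O)=O)cc1)c1ccccc12` differs from compound 1 in one place: 4-sulfamoylphenyl in place of 2-bromophenyl on an aromatic nitrogen. Going by the values given here, the only measured step, from compound 1 to compound 2, also exchanges the group on the aromatic nitrogen, but its size cannot be read, because both values sit at the limit of > 50000 nM in this assay, at which 2 of the 2 values shown sit. No readable step bears on the change to compound 3, so no direction beyond the scatter can be expected. With compound 1 known only as a limit, the estimate for compound 3 is 60000 nM, within 15000 nM and 250000 nM. This means an expected step that the limit leaves unreadable from compound 1 to compound 3, most likely again reported only as a limit.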

Compound 3, half-maximal inhibitory concentration: 31200 nM
Compound 3: the middle estimate sits 1.9-fold (0.28 log units) above what was measured; the range from low to high includes it.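

In this assay, going by these compounds alone, compound 3 gives 31200 nM, the first value that is a number and not a limit, so with 4-sulfamoylphenyl on the aromatic nitrogen the read-out comes inside the range of the assay on the shared core. The exchange of the 2-bromophenyl gives an at least 1.6-fold lower number from compound 1 to compound 3 (0.20 log units; that floor lies within the scatter), and sulfamoyl in place of methoxy on the aromatic carbon gives an at least 1.6-fold lower number from compound 2 to compound 3 (0.20 log units; that floor lies within the scatter). Neither step shows a difference beyond the scatter, and their true sizes stay unknown because the other end of each is not a number: the limit of > 50000 nM in this assay, at which 2 of the 3 values shown sit.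

What the compounds shown leave open is whether the number of compound 3 belongs to the sulfamoyl group in particular, or whether a carboxylic acid or an amine in its place on the phenyl ring would also give a number in this assay. Also open, from the compounds shown here alone, is how far the read-out would move with a longer chain between the phenyl ring and the sulfamoyl group.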